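Imine series on a shared thiophene-fused core: toxicity notes

The source may hold more compounds than are shown below. What is called first, only, known or untested is meant among the compounds shown, and "the series" means these compounds.

In an ADME assay on HepG2 cells (Homo sapiens) for cytotoxicity, read by MTT assay, with a stated time of 72 h (on this read-out higher numbers stand for lower toxicity in this test and lower numbers for higher toxicity in this test), three compounds of the series have numbers. Compound 1 `Nc1sc2c(c1-c1nc3cc(Cl)ccc3s1)CCC2` gives 67.8 ug/mL. Compound 2 `Fc1ccc(/C=N/c2sc3c(c2-c2nc4ccccc4s2)CCC3)cc1` gives 302 ug/mL. Compound 3 `Clc1ccc(/C=N/c2sc3c(c2-c2nc4ccccc4s2)CCCC3)c(Cl)c1` gives 384 ug/mL, the highest of the three numbers; the gap to compound 1 lies beyond the scatter, while the gap to compound 2 lies within it, so compounds 2 and 3 cannot be separated on this read-out. Among the measured compounds shown here, no single-point step between measured compounds is available.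

Compound 4 `Oc1ccccc1/C=N/c1sc2c(c1-c1nc3ccccc3s1)CCCC2` has not been measured in this assay. It differs from compound 3 in one place: 2-hydroxyphenyl in place of 2,4-dichlorophenyl on a carbon with a double bond to nitrogen. For the measured compounds named here, the measured compounds give no step that isolates a substituent swap of this kind on the aryl group of the imine, so the direction is open. For compound 4 the step of a 1.5-fold lower number from compound 3 to compound 4 (0.19 log units; within the scatter) is expected to stay within the scatter or only just beyond it, toward a somewhat lower number. Compound 4 is therefore estimated at 250 ug/mL, with a range from 100 ug/mL to 500 ug/mL.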

Compound 4, half-maximal cytotoxic concentration: 114 ug/mL
Compound 4: middle estimate off by 2.2-fold (0.34 log units), on the high side; the range from low to high includes it.
By their numbers in this assay, from the lowest: compounds 1 and 4 (each within the scatter of the next); then compounds 2 and 3 (each within the scatter of the next).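

In this assay, among the compounds shown here, the earlier compounds offered no single-place step, and this pair gives the first: 2-hydroxyphenyl in place of 2,4-dichlorophenyl on a carbon with a double bond to nitrogen gives a 3.4-fold lower number from compound 3 to compound 4 (0.53 log units; beyond the scatter), a modest step beyond the scatter. The aryl group at this position can therefore shift the read-out toward higher toxicity in this test, with the shared core otherwise unchanged. Nothing at hand bears on the reason for this shift.

The swap removes both chlorines and brings in a hydroxyl at once, so the compounds shown do not separate these two parts of the change, and an unsubstituted phenyl or a methoxyphenyl at this position would be needed to do so. From the compounds shown here alone, whether the step carries over to the core of compound 2 also remains open.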